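The source may report more compounds than this note shows. Statements on the series, on what has been measured and on what is new or still open speak of the compounds shown alone.

Compound 2 `Cc1ncc([N+](=O)[O-])n1CCOc1ccc(F)cc1` has the lowest number among the three measured analogues: in a functional assay on HT-29 cells (Homo sapiens) for cytotoxicity, read by MTT assay, with a stated time of 24 h (a higher number here means a weaker inhibitor, a lower number a stronger inhibitor), compound 2 gives 102 ug/mL, compound 1 `Cc1ncc([N+](=O)[O-])n1CCOc1ccccc1` gives 134 ug/mL, and compound 3 `Cc1cc(OCCn2c([N+](=O)[O-])cnc2C)ccc1F` gives 140 ug/mL. Both gaps are within the scatter, so no ranking is claimed. Compound 4 `Cc1ncc([N+](=O)[O-])n1CCOc1ccc([N+](=O)[O-])cc1` is not yet measured; it differs from compound 2 by nitro in place of fluoro on an aromatic carbon. Within the data shown here, the steps that bear on this change are small: a 1.3-fold lower number from compound 1 to compound 2 (0.12 log units; within the scatter) and a 1.4-fold higher number from compound 2 to compound 3 (0.14 log units; within the scatter) were both within the scatter. On that basis, another change on the same aromatic ring is expected to give no step beyond the scatter, so the expected step is a 1.1-fold higher number from compound 2 to compound 4 (0.03 log units; within the scatter). Compound 4 is therefore estimated at 110 ug/mL, in a range from 55 ug/mL to 220 ug/mL.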

Compound 4, half-maximal inhibitory concentration: 116 ug/mL
Compound 4: middle estimate off by 1.1-fold (0.02 log units), on the low side, and the stated range covers the measured number.
By their numbers in this assay, from the lowest: compounds 2, 4, 1 and 3 (each within the scatter of the next).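

In this assay, nitro, with three heavy atoms and two hydrogen-bond acceptors, stands on the aromatic carbon para to a large group, and both steps stay within the scatter: with nitro in place of fluoro there is a 1.1-fold higher number from compound 2 to compound 4 (0.06 log units; within the scatter) and with nitro in place of hydrogen there is a 1.2-fold lower number from compound 1 to compound 4 (0.06 log units; within the scatter). Among these compounds, this position, earlier seen only with hydrogen and fluoro, thus takes a group of more heavy atoms, with hydrogen-bond acceptors, without a step beyond the scatter. Nothing at hand explains this result. The compounds shown leave open whether an amine or a carboxylic acid at this position would give a step beyond the scatter. They also leave open whether a longer chain between the core and the aromatic ring would do so.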